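Propyl in place of chloro on the amide aryl ring

This account rests on a few compounds, and the source may have more. Where it says the series, first, only, none or still open, it means among the compounds named here.

Compound 1 `O=C(Nc1cccc(-c2oc3cc(-c4ccc(F)cc4)ccc3c(=O)c2O)c1)c1ccc(Cl)cc1` is the stronger-looking of the two measured compounds, though only by a margin that means nothing. In a functional assay on MCF7 cells (Homo sapiens) for antiproliferative activity, read by CCK-8 assay, with a stated time of 72 h (on this read-out lower numbers stand for stronger inhibition and higher numbers for weaker inhibition), compound 1 gives 4730 nM. Among the measured compounds shown here, its one measured neighbour, compound 2 `O=C(Nc1cccc(-c2oc3cc(-c4ccc(F)cc4)ccc3c(=O)c2O)c1)c1cccc(F)c1`, gives 5770 nM in this assay, and the step of a 1.2-fold higher number from compound 1 to compound 2 (0.09 log units; within the scatter) is too small to count as a real difference.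

Compound 3 `CCCc1ccc(C(=O)Nc2cccc(-c3oc4cc(-c5ccc(F)cc5)ccc4c(=O)c3O)c2)cc1` is compound 1 with one change: propyl in place of chloro on an aromatic carbon. For the measured compounds named here, no measured step touches this change directly; the single step known, from compound 1 to compound 2, swaps one halogen-bearing ring for another and was within the scatter, so it offers no guidance on replacing chloro with a three-carbon chain. With nothing to point either way, the expectation is a step of no more than the usual scatter in this assay, with a wide margin of doubt.

Compound 3 is therefore estimated at 4500 nM in this assay, within a range of 1500 nM to 13000 nM, which corresponds to an expected step of a 1.1-fold lower number from compound 1 to compound 3 (0.02 log units; within the scatter).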

Compound 3, half-maximal inhibitory concentration: 36800 nM
Estimate against measurement, compound 3: 8.2-fold (0.91 log units) below; measured number above the stated range.
By their numbers in this assay, from the lowest: compounds 1 and 2 (each within the scatter of the next); then compound 3.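

In this assay, the group on this position of the amide aryl ring clearly matters: propyl in place of chloro brings a 7.8-fold higher number from compound 1 to compound 3 (0.89 log units; beyond the scatter), whereas the earlier swap between two halogen-bearing rings produced no real difference. The second comparison agrees, as 4-propylphenyl in place of 3-fluorophenyl brings a 6.4-fold higher number from compound 2 to compound 3 (0.80 log units; beyond the scatter), so the weaker inhibition appears whichever halogen-bearing compound serves as the reference. No measurement on hand explains why this change weakens the result, so the data record only its size, not its cause.

On these data alone, it remains open whether the drop follows from the length of the carbon chain or from the loss of a halogen on the ring, and a methyl or ethyl group in the same place would help separate these two readings. An amine, a methoxy group or a carboxylic acid there would test whether groups of a quite different kind are accepted on this ring, and whether any of them can match or improve on compound 1.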